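Swapping the Dichlorophenyl Group in a Series at Its Limit

The source may report more compounds than this note shows. Statements on the series, on what has been measured and on what is new or still open speak of the compounds shown alone.

Measured so far in an ADME assay on HEK293 cells (Homo sapiens) for cytotoxicity, read by CellTiter-Glo and resazurin assay, with a stated time of 72 h (a lower number here means that less compound is needed, a higher number that more compound is needed for the effect), all three as limits:
Compound 1 `CC(C)Oc1cccc(-c2ccc(C(=O)N(Cc3cccc(OCCCCCC(=O)O)c3)C(C)C)cc2)c1` gives > 26000 nM as a limit
Compound 2 `CC(C)N(Cc1cccc(OCCCCCC(=O)O)c1)C(=O)c1ccc(-c2cccc(OCc3ccccc3)c2)cc1` gives > 26000 nM as a limit
Compound 3 `CC(C)N(Cc1cccc(OCCCCCC(=O)O)c1)C(=O)c1ccc(-c2ccc(Cl)c(Cl)c2)cc1` gives > 26000 nM as a limit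

Compound 3 has no number yet, only a limit. The whole measured set shares this position, at the limit of > 26000 nM in this assay, at which 3 of the 3 values shown sit, so the rank of compound 3 within it cannot be told.

Compound 4 `CC(C)N(Cc1cccc(OCCCCCC(=O)O)c1)C(=O)c1ccc(-c2cccc(S(C)(=O)=O)c2)cc1` makes one change to compound 3: 3-(methylsulfonyl)phenyl in place of 3,4-dichlorophenyl on an aromatic carbon with 3-(methylsulfonyl)phenyl in place of 3,4-dichlorophenyl on an aromatic carbon, para to a large group.

Among the compounds with values here, two measured steps bear on this. The closer one is a step that the two limits leave unreadable from compound 1 to compound 3 which also replaces one group with another on an aromatic carbon. The other is a step that the two limits leave unreadable from compound 1 to compound 2 with benzyl in place of isopropyl on an oxygen on an aromatic ring. Neither has a readable size, so neither gives the new change a direction. Compound 3 at > 26000 nM is itself a limit, so the starting point is not a number either. The expected a number no higher from compound 3 to compound 4 (the limit leaves the size open) is therefore nothing beyond the scatter, in neither direction. For compound 4 the estimate is 26000 nM with an expected range from 15000 nM to 50000 nM and the result will most likely be reported as a limit again.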

Compound 4, half-maximal effective concentration: > 26000 nM
Compound 4: only a limit was reported; the forecaster's own chance of this, stated with the estimate: 90%; the middle value lies on the limit itself.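

In this assay compound 4 gives > 26000 nM, a limit and not a number. None of the steps to it from compound 1, compound 2 or compound 3 can be read, and all four compounds share one position: the limit of > 26000 nM in this assay, at which 4 of the 4 values shown sit.

The compounds shown leave open which change, if any, moves the value, and by how much.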